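The source may report more compounds than this note shows. Statements on the series, on what has been measured and on what is new or still open speak of the compounds shown alone.

Compound 1 `COc1cc(NC(C)CCCNC(=O)NNC(=O)Nc2cc(C(F)(F)F)cc(C(F)(F)F)c2)c2ncccc2c1` has the shared core of this series carrying a trifluoromethyl-bearing aromatic ring through a urea linkage. In a functional assay on NCI-H460 cells (Homo sapiens) for inhibition, read by MTT assay, with a stated time of 72 h (a lower number here means a stronger inhibitor, a higher number a weaker inhibitor), compound 1 gives 18000 nM, and this is the lowest of the two numbers recorded so far. Its nearest neighbour, compound 2 `COc1cc(NC(C)CCCNC(=O)Nc2ccc(O)cc2)c2ncccc2c1`, gives 34000 nM in this assay, and the gap between the two lies within the scatter, so no order between them can be claimed. Compound 3 `COc1cc(NC(C)CCCNC(=O)NNC(=O)Nc2cccc(C(F)(F)F)c2)c2ncccc2c1`, not yet measured, differs from compound 1 in one place: hydrogen in place of trifluoromethyl on an aromatic carbon. Among the compounds with values here, no step between measured compounds covers a change of this kind, so the size of the step from compound 1 to compound 3 is uncertain; a small loss is expected, possibly none beyond the scatter. Compound 3 is therefore expected to give about 25000 nM, between 9000 nM and 70000 nM, which corresponds to an expected step of a 1.4-fold higher number from compound 1 to compound 3 (0.14 log units; within the scatter).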

Compound 3, half-maximal inhibitory concentration: 20000 nM
Compound 3: middle estimate off by 1.3-fold (0.10 log units), on the high side; the range from low to high includes it.
By their numbers in this assay, from the lowest: compounds 1, 3 and 2 (each within the scatter of the next).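

Within the data shown here, compound 3 gives the first direct reading of this change: in this assay, hydrogen in place of trifluoromethyl on an aromatic carbon, meta to a trifluoromethyl group, gives a 1.1-fold higher number from compound 1 to compound 3 (0.05 log units; within the scatter). Compound 1 and compound 3 therefore cannot be told apart in this assay, and the trifluoromethyl group at this position is not needed to keep the reading seen with compound 1. Nothing measured here explains this result.

The compounds shown leave open whether an amine, a carboxylic acid or a methoxy group at this position would give a reading beyond the scatter from that of compound 3. They also leave open what hydrogen would do in place of the remaining trifluoromethyl group of compound 3.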